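This account rests on a few compounds, and the source may have more. Where it says the series, first, only, none or still open, it means among the compounds named here.

Compound 1 `O=C(N1CCC=C[C@@H]1COCc1ccccc1)n1cc(-c2ccccc2)nn1` gives 158 nM in an assay on HEK293 cells for inhibition of Monoacylglycerol lipase ABHD6 (Homo sapiens), read by fluorescence; on this read-out higher numbers stand for weaker inhibition and lower numbers for stronger inhibition.
Compound 2 `O=C(N1CCC=C[C@@H]1COCc1ccccc1)n1cc(-c2ccc([N+](=O)[O-])cc2)nn1` gives 31.6 nM in this assay.
Compound 3 `O=C(N1CCC=C[C@@H]1COCc1ccccc1)n1cc(-c2ccc(Br)cc2)nn1` gives 15.9 nM in this assay.

Compound 3 has the lowest number of the three in this assay. Its distance from compound 1 is clear, a 9.9-fold lower number from compound 1 to compound 3 (1.00 log units; beyond the scatter), while its distance from compound 2 is a 2.0-fold lower number from compound 2 to compound 3 (0.30 log units; within the scatter), so compound 2 and compound 3 cannot be told apart.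

Compound 4 `O=C(N1CCC=C[C@@H]1COCc1ccccc1)n1cc(-c2ccc(Oc3ccccc3)cc2)nn1` keeps the shared core of compound 3 and changes only the group on the outer ring: phenoxy in place of bromo on an aromatic carbon. The measured steps that bear on this place are the two from compound 1, where a substituent entering at the position of the former hydrogen lowered the number each time, a 5.0-fold lower number from compound 1 to compound 2 (0.70 log units; beyond the scatter) and a 9.9-fold lower number from compound 1 to compound 3 (1.00 log units; beyond the scatter), and the step of a 2.0-fold lower number from compound 2 to compound 3 (0.30 log units; within the scatter), where exchanging one substituent for another changed little. Among the measured compounds shown here, a phenoxy group is much larger than either, and no measured compound carries a group of this size there, so the expectation is uncertain. A small step, if any, is expected in this assay: the estimate for compound 4 is 25 nM, with a range from 6 nM to 100 nM, meaning an expected step of a 1.6-fold higher number from compound 3 to compound 4 (0.20 log units; within the scatter).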

Compound 4, half-maximal inhibitory concentration: 6.31 nM
Beside the measured number, compound 4's estimate is 4.0-fold (0.60 log units) above it; low and high end bracket the measured number.
By their numbers in this assay, from the lowest: compound 4; then compounds 3 and 2 (each within the scatter of the next); then compound 1.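

The place on the outer ring accepts far more than a single atom: the phenoxy group, with its extra aromatic ring, gives a 2.5-fold lower number from compound 3 to compound 4 (0.40 log units; beyond the scatter) in this assay and does not push the number back up. Against the nitro compound, the exchange gives a 5.0-fold lower number from compound 2 to compound 4 (0.70 log units; beyond the scatter) and the full change from hydrogen gives a 25-fold lower number from compound 1 to compound 4 (1.40 log units; beyond the scatter) so compound 4 is the strongest inhibitor of the four in this series. No measurement at hand explains why the larger group gives the lower number.

The compounds shown cannot say whether the gain depends on the oxygen or on the second ring, which a directly attached phenyl group or a benzyloxy group would help to separate. Going by these compounds, how far this place can grow also remains open, for example with a chlorine on the outer ring of the phenoxy group.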